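Phenyl Gives Way to 2-(2-hydroxyethoxy)ethyl

This account rests on a few compounds, and the source may have more. Where it says the series, first, only, none or still open, it means among the compounds named here.

In a functional assay on RAW264.7 cells (Mus musculus) for inhibition, read by ELISA, with a stated time of 24 h (a higher number here means that more compound is needed for the effect, a lower number that less compound is needed), compound 1 `CC/C=C\C[C@H]1C(=O)C=C[C@H]1CC(=O)Oc1ccccc1` gives 33000 nM and stands level with compound 2 `CC/C=C\C[C@H]1C(=O)C=C[C@H]1CC(=O)Oc1ccccc1OC` at 32000 nM within the scatter. The change to compound 3 `CC/C=C\C[C@H]1C(=O)C=C[C@H]1CC(=O)OCCOCCO` is 2-(2-hydroxyethoxy)ethyl in place of phenyl on an oxygen next to a carbonyl group and puts 2-(2-hydroxyethoxy)ethyl in place of phenyl on an oxygen next to a carbonyl group. Among the measured compounds shown here, the only measured step of a 1.0-fold lower number from compound 1 to compound 2 (0.01 log units; within the scatter) is methoxy in place of hydrogen on an aromatic carbon. It keeps the phenyl ring, so it says little about losing that ring. No clear step is therefore expected in this assay in either direction. Compound 3 is estimated at 35000 nM with 12000 nM to 100000 nM as the expected range. That means an expected 1.1-fold higher number from compound 1 to compound 3 (0.03 log units; within the scatter) and remains a rough estimate.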

Compound 3, half-maximal effective concentration: 36000 nM
Compound 3: middle estimate off by 1.0-fold (0.01 log units), on the low side; the measured number falls inside the stated range.
By their numbers in this assay, from the lowest: compounds 2, 1 and 3 (each within the scatter of the next).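

In this assay, there is a 1.1-fold higher number from compound 1 to compound 3 (0.04 log units; within the scatter) when 2-(2-hydroxyethoxy)ethyl stands in place of phenyl on an oxygen next to a carbonyl group. The aromatic ring can therefore be lost at this position without a measurable shift, which the methoxy change could not show since it kept the ring. No supporting measurement explains why these two groups read alike. From the compounds shown here alone, whether an amine, a carboxylic acid or a longer chain on this oxygen would shift the number remains open. So does whether any change here can move it beyond the scatter.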